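The source may hold more compounds than are shown below. What is called first, only, known or untested is meant among the compounds shown, and "the series" means these compounds.

Compound 1, `CN(C)c1ncnc2[nH]cc(Sc3cccs3)c12`, is measured in a functional assay on HepG2 cells (Homo sapiens) for cytotoxicity, read by XTT assay, with a stated time of 6 days; a higher number here means a weaker inhibitor, a lower number a stronger inhibitor. Compound 1 gives > 25000 nM, which is a limit of the assay and not a number. Among the compounds with values here, its one measured neighbour is compound 2, `c1csc(Sc2c[nH]c3ncnc(-c4cccs4)c23)c1`, which carries thiophen-2-yl in place of dimethylamino on an aromatic carbon. Compound 2 gives > 25000 nM, again only a limit. The whole record therefore comes down to the limit of > 25000 nM in this assay, at which 2 of the 2 values shown sit.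

Compound 3, `COc1ncnc2[nH]cc(Sc3cccs3)c12`, has methoxy in place of dimethylamino on that same aromatic carbon: methoxy in place of dimethylamino on an aromatic carbon. Within the data shown here, the only measured step at this carbon is a step that the two limits leave unreadable from compound 1 to compound 2, so it offers no size and no direction to carry over. All it shows is that compound 2 stayed at its limit of > 25000 nM after a larger group replaced dimethylamino.

No step beyond the scatter is therefore expected in this assay, and a reading at the same limit is the likeliest result. The estimated step is a number no higher from compound 1 to compound 3 (the limit leaves the size open), with no direction expected. Compound 3 is expected at 25000 nM, with an estimated range of 10000 nM to 50000 nM.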

Compound 3, half-maximal inhibitory concentration: > 25000 nM
Compound 3: only a limit was reported (the forecaster's own chance of this, stated with the estimate: 75%); the middle value sits exactly at the limit.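

Compound 3 also gives only a limit of the assay, so its steps from compound 1 and from compound 2 cannot be read, in size or in direction: the limit of > 25000 nM in this assay, at which 3 of the 3 values shown sit. The compounds shown leave open how dimethylamino, thiophen-2-yl and methoxy on this aromatic carbon compare in this assay, where none of the three yields a number.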